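Working notes on tolerance across three amides

The source may hold more compounds than are shown below. What is called first, only, known or untested is meant among the compounds shown, and "the series" means these compounds.

Measured so far:
- compound 1 `COC(=O)c1sccc1NC(=O)CSc1nncnc1-c1ccccc1Cl` in an ADME assay on MT4 cells (Homo sapiens) for cytotoxicity, read by MTT assay (a higher number here means that more compound is tolerated, a lower number that less compound is tolerated), gives 105000 nM
- compound 2 `Cc1ccc(NC(=O)CSc2nncnc2-c2ccccc2Cl)c([N+](=O)[O-])c1` gives 158000 nM

Compound 1 holds the lower of the two numbers, and compound 2 stands within the scatter of it, so the two are not separated. Compound 3 `O=C(CSc1nncnc1-c1ccccc1Cl)Nc1ccccc1F` is not yet measured. It differs from compound 1 by 2-fluorophenyl in place of 2-(methoxycarbonyl)thiophen-3-yl on an amide-type nitrogen. Going by the values given here, no measured pair shows a step for such a change, and the two numbers available give no direction, so the step of a 1.1-fold higher number from compound 1 to compound 3 (0.06 log units; within the scatter) is expected to stay within the scatter. Compound 3 is expected to give 120000 nM in this assay, within 50000 nM to 300000 nM.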

Compound 3, half-maximal cytotoxic concentration: 98000 nM
Estimate against measurement, compound 3: 1.2-fold (0.09 log units) above; measured number inside the range.
By their numbers in this assay, from the lowest: compounds 3, 1 and 2 (each within the scatter of the next).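

In this assay the exchange of 2-(methoxycarbonyl)thiophen-3-yl for 2-fluorophenyl on the amide-type nitrogen gives a 1.1-fold lower number from compound 1 to compound 3 (0.03 log units; within the scatter) and leaves the two compounds unseparated. Going by these compounds alone, this is the first step read at this position, and it shows that replacing the thiophene ring and its methoxycarbonyl group with a fluorinated six-membered carbon ring does not separate the numbers. Nothing measured here gives a reason for this result.

The compounds shown leave open whether any group on this nitrogen separates from these two. As far as these compounds go, a carboxylic acid, an amine or a longer alkyl chain in that place remains untested in these data.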